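Methoxy to acetoxy on compound 2

The compounds below may be only part of what the source reports. "The series", "measured", "known", "first", "only" and "open" are said of these compounds alone.

Within the data shown here, three compounds have numbers so far in a functional assay on HeLa cells (Homo sapiens) for cytotoxicity (a lower number here means a stronger inhibitor, a higher number a weaker inhibitor), and no pair among them differs in one place only. Compound 2 (`COc1ccc2c(c1)C(=O)C=CC2=O`) gives 22700 nM and is the starting point here. Compound 3 (`Cc1ccc(S(=O)(=O)OC2=CC(=O)c3ccccc3C2=O)cc1`) gives 12200 nM and lies within the scatter of compound 2, so the two are not separated. Compound 1 (`O=C(OC1=CC(=O)c2ccccc2C1=O)c1ccccc1`) gives 55000 nM and this number is higher than that of compound 2, beyond the scatter.

Compound 4 (`CC(=O)Oc1ccc2c(c1)C(=O)C=CC2=O`) carries acetyl in place of methyl on an oxygen on an aromatic ring. Among the measured compounds shown here, no measured pair isolates this change. For the measured compounds named here, the only indirect guide is thin: compound 1 (55000 nM) and compound 3 (12200 nM) also carry an acylated or sulfonylated oxygen, but they differ from compound 2 in more than one place and give no direction. Only a small change is therefore expected, with low confidence in its sign. The estimated step of a 1.4-fold lower number from compound 2 to compound 4 (0.15 log units; within the scatter) is expected to stay within the scatter of repeated measurements. In this assay the estimate for compound 4 is 16000 nM (expected range 6000 nM to 45000 nM).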

Compound 4, half-maximal inhibitory concentration: 27700 nM
Compound 4: the middle estimate sits 1.7-fold (0.24 log units) below what was measured; measured number inside the range.
By their numbers in this assay, from the lowest: compounds 3, 2, 4 and 1 (each within the scatter of the next, the first and the last beyond it).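

In this assay, among these compounds, the exchange of methoxy for acetoxy on an oxygen on an aromatic ring gives a 1.2-fold higher number from compound 2 to compound 4 (0.09 log units; within the scatter), and this is the first step that isolates a change in one place. Compound 2 and compound 4 are therefore not separated: this oxygen carries either methyl or acetyl without a readable shift in the number, although acetyl brings a carbonyl and a hydrogen-bond acceptor that methyl lacks. No accompanying measurement bears on this result, so the flat step stands as an observation only.

What the compounds shown leave open is whether any group on this oxygen can move the number beyond the scatter, for example a longer chain such as butyryl, a chain ending in an amine, or one ending in a carboxylic acid. Among the compounds shown here, compound 1 and compound 3 differ from compound 4 in more than one place, so steps to them cannot be read, and the single flat step gives no trend for this position.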